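Nitrile to carbamoyl side chain on compound 1

The source may hold more compounds than are shown below. What is called first, only, known or untested is meant among the compounds shown, and "the series" means these compounds.

Within the data shown here, in a functional assay on EBC-1 cells (Homo sapiens) for antiproliferative activity, with a stated time of 72 h (a higher number here means a weaker inhibitor, a lower number a stronger inhibitor), compound 1 `N#Cc1ccc(-c2cc(F)c3ncc(Cc4ccc5ncccc5c4)n3c2)cc1F` gives 145 nM, the lower of the two numbers measured so far. Compound 2 `CNC(=O)c1cccc(-c2cc(F)c3ncc(Cc4ccc5ncccc5c4)n3c2)c1` gives 400 nM.

Compound 3 `CN(C)CCNC(=O)c1ccc(-c2cc(F)c3ncc(Cc4ccc5ncccc5c4)n3c2)cc1F` keeps the core of compound 1 and differs from it in one place: (2-(dimethylamino)ethyl)carbamoyl in place of cyano on an aromatic carbon. Here (2-(dimethylamino)ethyl)carbamoyl stands in place of cyano on an aromatic carbon, ortho to a fluoro group and para to a large group.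

Among the measured compounds shown here, one measured step bears on this change: a 2.8-fold higher number from compound 1 to compound 2 (0.44 log units; beyond the scatter). That modest step also takes away the cyano group and brings in a carbamoyl, but it removes the fluoro group as well. For the measured compounds named here, no measured compound carries the new chain, so the guide is indirect. On the evidence of compound 2 at 400 nM, a modest move towards a higher number is expected, with wide uncertainty. The expected step is a 2.2-fold higher number from compound 1 to compound 3 (0.34 log units; beyond the scatter). For compound 3 the estimated value is 320 nM, with an expected range of 110 nM to 900 nM.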

Compound 3, half-maximal inhibitory concentration: 49 nM
Beside the measured number, compound 3's estimate is 6.5-fold (0.81 log units) above it; the measured number lies below the stated range.
By their numbers in this assay, from the lowest: compound 3; then compound 1; then compound 2.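

In this assay, (2-(dimethylamino)ethyl)carbamoyl in place of cyano gives a 3.0-fold lower number from compound 1 to compound 3 (0.47 log units; beyond the scatter), so this aromatic carbon, ortho to a fluoro group, tolerates a rise from 2 to 8 heavy atoms without any loss in this read-out. The earlier step, a 2.8-fold higher number from compound 1 to compound 2 (0.44 log units; beyond the scatter), therefore cannot be read as a penalty for any carbamoyl replacing the nitrile: it exchanged the whole 4-cyano-3-fluorophenyl group for 3-(methylcarbamoyl)phenyl, and compound 3 shows that a carbamoyl-bearing chain can move the number the other way, with compound 2 standing against any general rule. Nothing available explains why the number falls for compound 3.

The compounds shown do not separate the contribution of the amide from that of the dimethylamino group, so a simple methylcarbamoyl on this same carbon with the fluoro group kept, a chain ending in morpholine or a carboxylic acid, and a longer chain remain the informative comparisons. Also open, on these data alone, is what the fluoro group contributes to compound 3, which a hydrogen in its place would address.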